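Pyrazolyl for methoxy: what to expect for compound 3

The source may report more compounds than this note shows. Statements on the series, on what has been measured and on what is new or still open speak of the compounds shown alone.

Measured so far:
- compound 1 `c1ccc(-c2cccc3c2CCC3c2ncc[nH]2)nc1`: in a functional assay on CHO cells for agonist activity at Alpha-1D adrenergic receptor (Homo sapiens), read by FLIPR and calcium flux (a higher number here means that more compound is needed for the effect, a lower number that less compound is needed), compound 1 gives > 10000 nM, which is a limit of the assay and not a number.
- compound 2 `COc1cccc2c1CCC2c1ncc[nH]1`: in this assay compound 2 gives > 10000 nM, again a limit rather than a number.

Compound 2 therefore stands at the limit of > 10000 nM in this assay, at which 2 of the 2 values shown sit. Among the measured compounds shown here, the only measured step that touches it is a step that the two limits leave unreadable from compound 1 to compound 2, so no size can be read from it.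

The new compound is compound 3 `Cn1nccc1-c1cccc2c1CCC2c1ncc[nH]1`. Relative to compound 2 the change is 1-methyl-1H-pyrazol-5-yl in place of methoxy on an aromatic carbon; in words, 1-methyl-1H-pyrazol-5-yl in place of methoxy on an aromatic carbon.

Nothing measured here gives a readable size for any change at this position; both measured values sit at the limit. The expectation for compound 3 in this assay is therefore that it stays at the limit as well, with a step that the limit leaves unreadable from compound 2 to compound 3 expected from compound 2, not beyond the scatter. The estimated value for compound 3 is 15000 nM, with an expected range from 3000 nM to 60000 nM.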

Compound 3, half-maximal effective concentration: > 10000 nM
Compound 3 ended at the assay's limit; the forecaster's own chance of this, stated with the estimate: 75%; the middle value does not contradict the limit.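

No step can be read in this assay among compound 1, compound 2 and compound 3, since each value is a limit and not a number: the limit of > 10000 nM in this assay, at which 3 of the 3 values shown sit.

What the compounds shown leave open is whether any group at this aromatic carbon gives a readable value in this assay, and so how pyridin-2-yl, methoxy and 1-methyl-1H-pyrazol-5-yl compare.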